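The compounds below may be only part of what the source reports. "The series", "measured", "known", "first", "only" and "open" are said of these compounds alone.

Working notes on the series.

Compound 1 `CCCOC(=O)[C@@H](N)CCC(=O)NCCSC(=O)c1ccccc1` gives 0.167 h in an ADME assay on liver for metabolic stability, with liver carboxylesterase 1 (Homo sapiens) as the target; on this read-out higher numbers stand for a longer-lived compound and lower numbers for a shorter-lived compound. Compound 2 `CCOC(=O)[C@@H](N)CCC(=O)NCCSC(=O)C(C)(C)C` gives 0.167 h in this assay, which stands level with compound 1 at the digits shown; the two values sit within the usual scatter of each other, so no order between them can be read. Going by the values given here, no step between the two measured compounds is recorded, and they differ in more than one place, so only their two values speak here.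

Compound 3 `CCOC(=O)[C@@H](N)CCC(=O)NCCSC(=O)c1ccccc1` has not yet been measured in this assay. Compound 3 differs from compound 2 in one place: phenyl in place of tert-butyl on a carbonyl carbon. The same phenyl group on the carbonyl carbon is already present in compound 1, which gives 0.167 h in this assay, and that value does not stand apart from compound 2. On this basis the step from compound 2 to compound 3 is expected to be small, no change at the digits printed from compound 2 to compound 3 (within the scatter), with no direction beyond the scatter. Compound 3 is therefore estimated at 0.167 h in this assay, within a range from 0.08 h to 0.35 h.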

Compound 3, half-life in the liver carboxylesterase 1 assay: 0.167 h
Compound 3: middle estimate and measured number agree at the digits printed; the measured number falls inside the stated range.
By their numbers in the liver carboxylesterase 1 assay, from the lowest: compounds 1, 2 and 3 (each within the scatter of the next).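

In the liver carboxylesterase 1 assay, phenyl in place of tert-butyl on a carbonyl carbon gives no change at the digits printed from compound 2 to compound 3 (within the scatter) in a single-place comparison, which the earlier pair, differing in more than one place, could not provide. The ester side can now be read as well: hydrogen in place of methyl on a saturated chain carbon, two bonds along the chain from an oxygen next to a carbonyl group, gives no change at the digits printed from compound 1 to compound 3 (within the scatter) and so does not separate the two compounds in this read-out. In a physicochemical assay for acid dissociation, using potentiometric titration, at pH 2, compound 2 gives 8.9 and compound 3 gives 8.85, and a number 0.05 log units lower from compound 2 to compound 3 (within the scatter) shows that the exchange on the carbonyl carbon does not separate them on this read-out either.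

Going by these compounds, the half-life with an amine or a longer chain on this carbonyl carbon stays open, as does the half-life with a carboxylic acid in place of the ester. Nothing available here bears on why the half-lives of these compounds coincide.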